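Moving a hydroxyl on a triaryl pyridine against topoisomerase

The source may hold more compounds than are shown below. What is called first, only, known or untested is meant among the compounds shown, and "the series" means these compounds.

Of the compounds shown here, three sharing one core have been tested. Compound 1 `Oc1ccc(-c2cc(-c3cccs3)cc(-c3ccc(O)cc3)n2)cc1` gives 0.9% in an assay on isolated protein for inhibition of DNA topoisomerase 1 (Homo sapiens), with a stated time of 30 min, tested at 20 uM; a lower number here means a weaker effect, a higher number a stronger effect of the compound at the concentration tested. Compound 2 `Oc1ccc(-c2cc(-c3ccoc3)cc(-c3ccc(O)cc3)n2)cc1` gives 0% in this assay; the step of a number 0.9 percentage points lower from compound 1 to compound 2 (within the scatter) shows that exchanging one five-membered ring for another at that position leaves the read-out where it was. Compound 3 `Oc1ccc(-c2cc(-c3cccnc3)cc(-c3ccccc3O)n2)cc1` gives 0% in this assay. Compound 3 therefore stands level with compound 2 at the digits reported, and its figure lies within the scatter of compound 1: all three show essentially no inhibition at the concentration used.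

Compound 4 `Oc1ccc(-c2cc(-c3cccnc3)cc(-c3ccc(O)cc3)n2)cc1` has not yet been measured. It differs from compound 3 only in one place: 4-hydroxyphenyl in place of 2-hydroxyphenyl on an aromatic carbon. Among the measured compounds shown here, no measured step touches this position; the single measured step, a number 0.9 percentage points lower from compound 1 to compound 2 (within the scatter), concerns a different ring and was itself within the scatter. For the measured compounds named here, the only guidance is that every compound so far, whatever the substituent, sits near zero.

Compound 4 is therefore expected to give 1% in this assay, with a plausible range from 0% to 10%. The expected step of a number 1 percentage points higher from compound 3 to compound 4 (within the scatter) is estimated to lie within the scatter, with no change in direction that the data would support.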

Compound 4, a percentage reported as inhibition, at one concentration (the size of the read-out at that concentration, not a potency): 5%
Compound 4: middle estimate off by 4 percentage points, on the low side; low and high end bracket the measured number.
By their numbers in this assay, from the lowest: compounds 2, 3, 1 and 4 (each within the scatter of the next).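

Moving the hydroxyl from 2-hydroxyphenyl to 4-hydroxyphenyl, on the aromatic carbon next to the ring nitrogen, is the first measured change at this position, and in this assay it gives a number 5 percentage points higher from compound 3 to compound 4 (within the scatter). The place of the hydroxyl on this ring therefore makes no readable difference here, and compound 4 also shows that pyridin-3-yl can be compared directly with the two five-membered rings, giving a number 5 percentage points higher from compound 2 to compound 4 (within the scatter) against furan-3-yl and a number 4.1 percentage points higher from compound 1 to compound 4 (within the scatter) against thiophen-2-yl. Nothing further is at hand to bear on these readings.

Every compound shown carries a hydroxyl on both phenyl rings, so it remains open whether an amine, a carboxylic acid or a methoxy group in its place would move the read-out beyond the usual scatter. Also open, going by these compounds, is how 3-hydroxyphenyl at this same position would read, as that would complete the set of places for the hydroxyl on this ring.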